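Replacing Quinolin-4-yl on the Carbonyl of Compound 3

This account rests on a few compounds, and the source may have more. Where it says the series, first, only, none or still open, it means among the compounds named here.

Compound 1, `COc1ccc(S(=O)(=O)Oc2ccccc2NC(=O)c2ccccn2)cc1`, gives 110 nM in a functional assay on HCT-15 cells (Homo sapiens) for antiproliferative activity; a higher number here means a weaker inhibitor, a lower number a stronger inhibitor.
Compound 2, `COc1ccc(S(=O)(=O)Oc2ccccc2NC(=O)c2ccc(F)cc2)cc1`, gives 89 nM in this assay.
Compound 3, `COc1ccc(S(=O)(=O)Oc2ccccc2NC(=O)c2ccnc3ccccc23)cc1`, gives only a limit in this assay, > 10000 nM.

The three measured compounds share a core and differ only in the group on the carbonyl carbon. Between compound 1 and compound 2 the step is a 1.2-fold lower number from compound 1 to compound 2 (0.09 log units; within the scatter). Moving to the quinolin-4-yl group is a different matter: an at least 90-fold higher number from compound 1 to compound 3 (1.95 log units; beyond the scatter) and an at least 110-fold higher number from compound 2 to compound 3 (2.05 log units; beyond the scatter). Compound 3 therefore stands at the weak end of the set, and its value is a limit, as shown by the limit of > 10000 nM in this assay, at which 1 of the 3 values shown sits.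

Compound 4, `COc1ccc(S(=O)(=O)Oc2ccccc2NC(=O)Oc2ccccc2)cc1`, carries the change (phenoxy in place of quinolin-4-yl on a carbonyl carbon). Among the compounds with values here, the steps that bear on it are the two large ones into compound 3, now run in reverse: the group that leaves is the one that cost most, and the group that enters is closer in size to the 4-fluorophenyl of compound 2. Compound 4 is therefore expected to give a much lower number, with an at least 25-fold lower number from compound 3 to compound 4 (1.39 log units; beyond the scatter). The estimate for compound 4 is 400 nM, with a range from 60 nM to 4000 nM.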

Compound 4, half-maximal inhibitory concentration: > 10000 nM
Compound 4 ended at the assay's limit; the forecaster's own chance of this, stated with the estimate: 20%; middle value at least 25-fold (1.39 log units) away from the limit.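

The group on the carbonyl carbon proves less forgiving than compound 3 alone could show: phenoxy has fewer heavy atoms than quinolin-4-yl and keeps one six-membered aromatic ring of carbon only, like the 4-fluorophenyl of compound 2, yet the steps are an at least 110-fold higher number from compound 2 to compound 4 (2.05 log units; beyond the scatter) and an at least 90-fold higher number from compound 1 to compound 4 (1.95 log units; beyond the scatter). In this assay compound 4 gives > 10000 nM, which is a limit, and the steps that rest on two limits cannot be read. Compound 3 and compound 4 now stand together: the limit of > 10000 nM in this assay, at which 2 of the 4 values shown sit.

Going by these compounds, how far apart compound 3 and compound 4 truly lie stays open. Also open, on these data alone, is whether a benzyl group or a piperidine on the carbonyl carbon would stay with compound 1 and compound 2 or fall with compound 3 and compound 4.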